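The source may report more compounds than this note shows. Statements on the series, on what has been measured and on what is new or still open speak of the compounds shown alone.

- Compound 1 `O=C1/C(=C/c2cccnc2)CNC/C1=C\c1ccccc1F`: > 20000 nM (a limit)
- Compound 2 `Cc1ccc(S(=O)(=O)N2C/C(=C\c3cccnc3)C(=O)/C(=C/c3ccccc3F)C2)cc1`: 10300 nM
- Compound 3 `O=C1/C(=C/c2ccncc2)CNC/C1=C\c1ccccc1F`: 18400 nM

In a functional assay on SMMC-7721 cells (Homo sapiens) for cytotoxicity, read by MTT assay, with a stated time of 24 h (a lower number here means a stronger inhibitor, a higher number a weaker inhibitor), compound 3 at 18400 nM and compound 2 at 10300 nM lie within the scatter of each other. Compound 1 stands at > 20000 nM as a limit, not a number. Compound 4 `O=C1/C(=C/c2ccncc2)CN(S(=O)(=O)c2ccc(Cl)cc2)C/C1=C\c1ccccc1F` differs from compound 3 by (4-chlorophenyl)sulfonyl in place of hydrogen on an amine nitrogen in a ring. On these data alone, the closest measured change, (4-methylphenyl)sulfonyl in place of that hydrogen, gave an at least 1.9-fold lower number from compound 1 to compound 2 (0.28 log units; that floor lies within the scatter) and starts from a limit, so its true size is unknown. The swap of pyridin-3-yl for pyridin-4-yl gave an at least 1.0-fold lower number from compound 1 to compound 3 (0.03 log units; that floor lies within the scatter) and points to no separate shift. Going by an at least 1.9-fold lower number from compound 1 to compound 2 (0.28 log units; that floor lies within the scatter) a small step toward a lower number is expected (a 1.9-fold lower number from compound 3 to compound 4 (0.29 log units; within the scatter)). Compound 4 is estimated at 9500 nM (expected range 3500 nM to 22000 nM).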

Compound 4, half-maximal inhibitory concentration: 9600 nM
The estimate for compound 4 lay 1.0-fold (0.00 log units) below the measured number; the range from low to high includes it.
By their numbers in this assay, from the lowest: compounds 4, 2 and 3 (each within the scatter of the next). At a limit, above all of these: compound 1.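

In this assay, a sulfonyl group on the amine nitrogen in the ring now has a step with a real number at both ends, a 1.9-fold lower number from compound 3 to compound 4 (0.28 log units; within the scatter) and so the size of this change is known, and it stays within the scatter. The earlier step from compound 1 gave only a floor because compound 1 is a limit: the limit of > 20000 nM in this assay, at which 1 of the 4 values shown sits.

On these data alone, what an acetyl group or a longer alkyl chain on this nitrogen would do stays open. Compound 2 and compound 4 also differ in a second place, so (4-methylphenyl)sulfonyl and (4-chlorophenyl)sulfonyl have no direct comparison.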